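The source may report more compounds than this note shows. Statements on the series, on what has been measured and on what is new or still open speak of the compounds shown alone.

The three measured compounds share one core, and they are compound 1 `CCOC(=O)C1=Cc2ccccc2OC1(OCc1cn(CC(=O)Nc2cccc(F)c2)nn1)C(F)(F)F`, compound 2 `CCOC(=O)C1=Cc2ccccc2OC1(OCc1cc(-c2ccc3ccccc3c2)no1)C(F)(F)F` and compound 3 `CCOC(=O)C1=Cc2ccccc2OC1(OCc1cc(-c2ccc(Cl)cc2)no1)C(F)(F)F`, all tested in a functional assay on MCF7 cells (Homo sapiens) for inhibition, read by MTT assay, with a stated time of 24 h; on this read-out higher numbers stand for weaker inhibition and lower numbers for stronger inhibition. In this assay compound 1 gives > 150000 nM, which is a limit of the assay and not a number. Where compound 1 stands on the numbers shown is therefore only (the limit of > 150000 nM in this assay, at which 1 of the 3 values shown sits). In this assay compound 2 gives 65400 nM, and compound 3 gives 18200 nM. Among the compounds with values here, the one step between measured compounds that differ in a single place is a 3.6-fold lower number from compound 2 to compound 3 (0.56 log units; beyond the scatter), and it concerns an aromatic carbon on a different side chain than the one now in view.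

Compound 4 `CCOC(=O)C1=Cc2ccccc2OC1(OCc1cn(CC(=O)Nc2ccc(I)cc2Cl)nn1)C(F)(F)F` differs from compound 1 by 2-chloro-4-iodophenyl in place of 3-fluorophenyl on an amide-type nitrogen. Within the data shown here, no measured step touches this amide-type nitrogen, so the step from compound 2 to compound 3 serves only as a rough gauge of how far such a change of an aryl group may move the number in this assay. Because compound 1 sits at the limit of > 150000 nM in this assay, at which 1 of the 3 values shown sits, compound 4 is expected to remain in the same weak region. Compound 4 is estimated at 120000 nM in this assay, with a range from 30000 nM to 300000 nM. The expected step is therefore an at least 1.2-fold lower number from compound 1 to compound 4 (0.09 log units; that floor lies within the scatter), with a real chance that only a limit is reported again.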

Compound 4, half-maximal inhibitory concentration: 28100 nM
Beside the measured number, compound 4's estimate is 4.3-fold (0.63 log units) above it, outside the stated range (below it).
By their numbers in this assay, from the lowest: compounds 3 and 4 (each within the scatter of the next); then compound 2. At a limit, above all of these: compound 1.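

In this assay, putting 2-chloro-4-iodophenyl in place of 3-fluorophenyl on the amide-type nitrogen gives an at least 5.3-fold lower number from compound 1 to compound 4 (0.72 log units; beyond the scatter). Within the data shown here, this is the first sign that the aryl group on this nitrogen can move the number beyond the scatter, since the only earlier step concerned an aromatic carbon on a different side chain. With 2-chloro-4-iodophenyl in this position, the side chain of compound 1 now gives a measured number rather than a limit, but the full size of the step remains unknown because the value for compound 1 is a limit of the assay and not a number: the limit of > 150000 nM in this assay, at which 1 of the 4 values shown sits.

The exchange removes one halogen and introduces two others at once, so the compounds shown cannot separate what the 2-chloro and 4-iodo substituents each contribute, and a simple 2-chlorophenyl or 4-iodophenyl group on this nitrogen would be needed to tell them apart. Also open, on these data alone, is how the number would respond to a phenyl ring carrying an amine or a carboxylic acid in this position, and whether 2-chloro-4-iodophenyl would have a similar effect in another side chain.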